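Bromine in Place of a Thiophenyl Arm: Expected Cell Tolerance

This account rests on a few compounds, and the source may have more. Where it says the series, first, only, none or still open, it means among the compounds named here.

Of the compounds shown here, three built on one shared core have been tested in an ADME assay on MDCK cells (Canis lupus familiaris) for cytotoxicity, read by microscopy, with a stated time of 48 h; a lower number here means that less compound is tolerated, a higher number that more compound is tolerated. Compound 1 `C[C@H]1[C@H](NCc2cccs2)C[C@H]2C[C@@H]1C2(C)C` gives 25000 nM. Compound 2 `C[C@H]1[C@H](NCc2ccc(Br)s2)C[C@H]2C[C@@H]1C2(C)C` gives 43000 nM, and the step of a 1.7-fold higher number from compound 1 to compound 2 (0.24 log units; within the scatter). Compound 3 `C[C@H]1[C@H](NCc2cc(-c3ccsc3)cs2)C[C@H]2C[C@@H]1C2(C)C` gives 25000 nM, the step of no change at the digits printed from compound 1 to compound 3 (within the scatter). Compound 3 therefore sits level with compound 1 at the digits reported, the two together being the lowest of the three numbers, with compound 2 the furthest away and still within the scatter.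

Compound 4 `C[C@H]1[C@H](NCc2cc(Br)cs2)C[C@H]2C[C@@H]1C2(C)C` is the next compound to be measured. It differs from compound 3 in one place: bromo in place of thiophen-3-yl on an aromatic carbon. Within the data shown here, two measured steps bear on this change. Adding bromo in the step from compound 1 to compound 2 and adding thiophen-3-yl in the step from compound 1 to compound 3 each stayed within the scatter, so neither group has shown a clear effect here. The expected step is a 1.4-fold higher number from compound 3 to compound 4 (0.15 log units; within the scatter), a small rise at most, not beyond the scatter. Compound 4 is expected to give 35000 nM, with a range from 18000 nM to 70000 nM.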

Compound 4, minimum cytotoxic concentration: 6250 nM
Estimate against measurement, compound 4: 5.6-fold (0.75 log units) above; measured number below the stated range.
By their numbers in this assay, from the lowest: compound 4; then compounds 1, 3 and 2 (each within the scatter of the next).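

In this assay, bromo at this position, two ring bonds from the ring sulfur, gives a 4.0-fold lower number from compound 1 to compound 4 (0.60 log units; beyond the scatter) when it replaces hydrogen and a 4.0-fold lower number from compound 3 to compound 4 (0.60 log units; beyond the scatter) when it replaces thiophen-3-yl, so here it separates from both groups beyond the scatter. The place of the bromine on the ring also counts, as 4-bromothiophen-2-yl in place of 5-bromothiophen-2-yl gives a 6.9-fold lower number from compound 2 to compound 4 (0.84 log units; beyond the scatter) even though compound 2 stayed within the scatter of compound 1. The larger thiophen-3-yl of compound 3 stayed level with hydrogen, so group size alone does not follow these numbers.

No measured evidence gives a reason for this drop. Chloro or methyl at the same position could show whether the lower number is particular to bromo or is shared by other small groups.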